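Hydroxyamino for hydroxymethyl on the shared core

The source may report more compounds than this note shows. Statements on the series, on what has been measured and on what is new or still open speak of the compounds shown alone.

Compound 2 `Cc1cc(C#N)cc(C)c1Nc1nc(Nc2ccc(C#N)cc2)nc(CO)c1Br` stands lowest of the two measured numbers in a physicochemical assay for lipophilicity (on this read-out lower numbers stand for lower lipophilicity and higher numbers for higher lipophilicity), giving 0.81; compound 1 `Cc1cc(C#N)cc(C)c1Nc1nc(Nc2ccc(C#N)cc2)ncc1Br` gives 1.39. Compound 3 `Cc1cc(C#N)cc(C)c1Nc1nc(Nc2ccc(C#N)cc2)nc(NO)c1Br` differs from compound 2 by hydroxyamino in place of hydroxymethyl on an aromatic carbon. For the measured compounds named here, the only measured step, a number 0.58 log units lower from compound 1 to compound 2 (beyond the scatter), concerns a different exchange and is modest in this assay. Compound 3 is therefore expected to sit close to compound 2, with a step of a number 0.21 log units lower from compound 2 to compound 3 (within the scatter) that is expected to lie within the scatter. For compound 3 the estimated value in this assay is 0.6, expected between 0 and 1.2.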

Compound 3, partition coefficient: 2.18
Compound 3: the middle estimate sits 1.58 log units below what was measured, outside the stated range (above it).
By their numbers in this assay, from the lowest: compound 2; then compound 1; then compound 3.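

In this assay, the aromatic carbon next to the ring nitrogen responds strongly to a change of group: hydroxyamino in place of hydroxymethyl gives a number 1.37 log units higher from compound 2 to compound 3 (beyond the scatter) on the shared core. Relative to hydrogen, the two groups move the number in opposite directions, with hydroxyamino giving a number 0.79 log units higher from compound 1 to compound 3 (beyond the scatter) and hydroxymethyl giving a number 0.58 log units lower from compound 1 to compound 2 (beyond the scatter) at the same carbon. Nothing available here explains this divergence. On these data alone, it remains open where an amine or a methoxy group at this carbon would fall relative to these compounds. As far as these compounds go, whether the same divergence holds on a different core is also open.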